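The source may report more compounds than this note shows. Statements on the series, on what has been measured and on what is new or still open speak of the compounds shown alone.

Measured so far in an assay on isolated protein for agonist activity at Bile acid receptor (Homo sapiens), read by FRET; on this read-out lower numbers stand for smaller maximal responses and higher numbers for larger maximal responses:

compound 1 `CC(C)c1onc(-c2c(Cl)cccc2Cl)c1COc1ccc(N(C)C(=O)c2cccc(C(=O)O)c2)c(C(F)(F)F)n1` — 110%
compound 2 `CN(Cc1cccc(C(=O)O)c1)c1ccc(OCc2c(-c3c(Cl)cccc3Cl)noc2C2CC2)nc1C(F)(F)F` — 102%
compound 3 `CN(Cc1ccc(C(=O)O)cc1)c1ccc(OCc2c(-c3c(Cl)cccc3Cl)noc2C2CC2)nc1C(F)(F)F` — 109%

Compound 3 stands second highest of the three numbers in this assay. Its nearest neighbour is compound 1 and its furthest is compound 2, and both of these differences lie within the scatter. Within the data shown here, the one step among measured compounds that differ in a single place, a number 7 percentage points higher from compound 2 to compound 3 (within the scatter), moves the carboxyphenyl attachment point and does not change the maximal response beyond the scatter.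

Compound 4 `CN(Cc1ccc(C(=O)NCCS(=O)(=O)O)cc1)c1ccc(OCc2c(-c3c(Cl)cccc3Cl)noc2C2CC2)nc1C(F)(F)F` is the next compound. It differs from compound 3 as follows: (2-sulfoethyl)amino in place of hydroxy on a carbonyl carbon. Among the measured compounds shown here, no measured pair shows this change, or any change of the carboxy group itself; the single measured step at this part of the structure, a number 7 percentage points higher from compound 2 to compound 3 (within the scatter), stayed within the scatter, and all three measured compounds sit close together near the top of the range. There is therefore nothing in the measured steps to suggest a move beyond the scatter, so a step of a number 4 percentage points lower from compound 3 to compound 4 (within the scatter) is expected, which is essentially none. The value of compound 4 in this assay is estimated at 105%, with a range from 85% to 125%.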

Compound 4, largest response reached (reported as efficacy), in percent of the reference or control that the assay uses: 105%
Compound 4: the middle estimate sits on the measured number at the digits printed; the measured number falls inside the stated range.
By their numbers in this assay, from the lowest: compounds 2, 4, 3 and 1 (each within the scatter of the next).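

In this assay, (2-sulfoethyl)amino in place of hydroxy on the carbonyl carbon gives a number 4 percentage points lower from compound 3 to compound 4 (within the scatter), so this position tolerates the exchange without a step beyond the scatter. Among these compounds, all the earlier compounds carry the carboxy group, whereas compound 4 shows that a maximal response within the scatter of compound 3 does not depend on keeping that group at this position, even with 7 heavy atoms entering where 1 leaves. No supporting data are available to explain this result.

Still open, going by these compounds, is how far this tolerance extends along the chain: a (2-carboxyethyl)carbamoyl group, a longer chain ending in the same sulfo group, or a plain primary amide could each separate the role of the terminal group from that of the amide. On these data alone, it also remains open whether (2-sulfoethyl)carbamoyl is tolerated in the same way on the 3-carboxyphenyl of compound 2 or on the carboxyphenyl of compound 1, where the surrounding structure differs.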